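From compound 3 to compound 4: one group exchanged

A few compounds are considered here, and "the series" means these few. Any claim that something is new, unique, unknown or untested is made for them only; others in the source may bear on it.

In an ADME assay on HEK293 cells (Homo sapiens) for cytotoxicity, read by CellTiter-Glo and resazurin assay, with a stated time of 72 h (on this read-out higher numbers stand for an effect only at larger amounts of compound and lower numbers for an effect already at smaller amounts), compound 3 (`CCOC(=O)CCCCCOc1cccc(CN(C(=O)c2ccc(-c3ccc4c(c3)OCCO4)cc2)C(C)C)c1`) gives > 24400 nM as a limit and not a number. Compound 1 (`CCOC(=O)CCCCCOc1cccc(CN(C(=O)c2ccc(-c3cccc(OCC(C)C)c3)cc2)C(C)C)c1`) gives > 26000 nM as a limit too. Compound 2 (`CCOC(=O)CCCCCOc1cccc(CN(C(=O)c2ccc(-c3cccc(Oc4ccccc4)c3)cc2)C(C)C)c1`) gives > 19600 nM as a limit as well. Compound 3 therefore stands among three limits, and none of the three compounds has a measured number.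

Compound 4 (`CCOC(=O)CCCCCOc1cccc(CN(C(=O)c2ccc(-c3cccc(F)c3)cc2)C(C)C)c1`) carries 3-fluorophenyl in place of 2,3-dihydro-1,4-benzodioxin-6-yl on an aromatic carbon, para to a large group (3-fluorophenyl in place of 2,3-dihydro-1,4-benzodioxin-6-yl on an aromatic carbon). Among the compounds with values here, two measured steps bear on this change. The exchange of 3-(isobutoxy)phenyl for 2,3-dihydro-1,4-benzodioxin-6-yl is a step that the two limits leave unreadable from compound 1 to compound 3 and the exchange of isobutyl for phenyl on an oxygen is a step that the two limits leave unreadable from compound 1 to compound 2 in the same assay. Neither has a readable size, so they offer no measured effect to carry over, only the observation that all three groups ended in a limit. No step beyond the scatter, in either direction, is expected in this assay for this exchange. The estimated step is a step that the limit leaves unreadable from compound 3 to compound 4 as an expectation only. Compound 4 is expected at 25000 nM within an estimated range from 12000 nM to 45000 nM and will most likely be reported as a limit again.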

Compound 4, half-maximal effective concentration: > 26000 nM
Compound 4 was reported as a limit; the forecaster's own chance of this, stated with the estimate: 85%; at least 1.0-fold (0.01 log units) between middle value and limit.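

Compound 4 is reported only as a limit, as are compound 1, compound 2 and compound 3, and none of the steps from those three compounds to compound 4 in this assay can be read. The compounds shown leave open at what concentration any of the four would reach a half-maximal effect, and whether the exchanged groups differ at all on this read-out.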